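Configuration at the ring carbon: compound 3 to compound 4

The compounds below may be only part of what the source reports. "The series", "measured", "known", "first", "only" and "open" are said of these compounds alone.

Measured in an ADME assay on MDCK cells (Canis lupus familiaris) for permeability, read by LC-MS, with a stated time of 90 min, tested at 2 uM; a higher number here means that the compound crosses the layer faster, a lower number that the compound crosses the layer more slowly:
- compound 1 `Cc1cc(C)c(CN2CCc3c(Cl)cc(C(CO)c4ccon4)c(Cl)c3C2=O)c(=O)[nH]1`: 5.8 10^-6 cm/s; 8.6 10^-6 cm/s (2 entries)
- compound 2 `Cc1cc(C)c(CN2CCc3c(Cl)cc([C@H](CO)[C@@H]4CCCO4)c(Cl)c3C2=O)c(=O)[nH]1`: 14.6 10^-6 cm/s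
- compound 3 `Cc1cc(C)c(CN2CCc3c(Cl)cc([C@@H](CO)[C@@H]4CCCO4)c(Cl)c3C2=O)c(=O)[nH]1`: 4.3 10^-6 cm/s

Not yet measured: compound 4 `Cc1cc(C)c(CN2CCc3c(Cl)cc([C@@H](CO)[C@H]4CCCO4)c(Cl)c3C2=O)c(=O)[nH]1`.

In this assay, compound 3 stands well under compound 2, with a 3.4-fold lower number from compound 2 to compound 3 (0.53 log units; beyond the scatter). The next change is the two compounds have the same atoms and bonds and differ only in configuration as drawn: 1 of 2 stereo elements differ; a stereocentre at a saturated ring carbon is drawn S in compound 3 and R in compound 4. Within the data shown here, the one measured step that bears on it is the same a 3.4-fold lower number from compound 2 to compound 3 (0.53 log units; beyond the scatter), and it comes with the fact that compounds 2 and 3 differ only in the configuration as drawn. That inversion lay at a saturated chain carbon, so its direction does not carry over to the ring carbon. Repeat spread is visible in the several entries of compound 1 in this assay, 5.8 10^-6 cm/s; 8.6 10^-6 cm/s (2 entries). A small rise, no larger than the measured step, is expected, since compound 3 at 4.3 10^-6 cm/s sits low in this set. The expected change is a 1.9-fold higher number from compound 3 to compound 4 (0.27 log units; within the scatter). For compound 4 the estimated value is 8 10^-6 cm/s, with an expected range of 3.5 10^-6 cm/s to 17 10^-6 cm/s.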

Compound 4, apparent permeability: 8.5 10^-6 cm/s
Estimate against measurement, compound 4: 1.1-fold (0.03 log units) below, within the range that was stated.
By their numbers in this assay, from the lowest: compounds 3, 4 and 2 (each within the scatter of the next, the first and the last beyond it).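

In this assay, among these compounds, inversion at the saturated ring carbon gives a 2.0-fold higher number from compound 3 to compound 4 (0.30 log units; within the scatter) and so does not separate the two compounds, whereas inversion at the saturated chain carbon gave a 3.4-fold lower number from compound 2 to compound 3 (0.53 log units; beyond the scatter) as the one step beyond the scatter. The mirror images also stay unresolved, with a 1.7-fold lower number from compound 2 to compound 4 (0.23 log units; within the scatter) as their step. Among these three stereoisomers, only compounds 2 and 3 are separated in this assay by more than the scatter.

Still open, from the compounds shown here alone, is how the ring-carbon inversion reads with the chain carbon drawn R. Also open is how a primary amine in place of the hydroxyl would read.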